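Trimming the alkyne chain of compound 1

A few compounds are considered here, and "the series" means these few. Any claim that something is new, unique, unknown or untested is made for them only; others in the source may bear on it.

In a functional assay on MOLT-4 cells (Homo sapiens) for antiproliferative activity, read by MTT assay, with a stated time of 3 days (on this read-out lower numbers stand for stronger inhibition and higher numbers for weaker inhibition), compound 1 `CCCCCCCCC#Cc1cn(C/C=C/CN2C(=O)c3ccccc3C2=O)c(=O)[nH]c1=O` gives only a limit, > 250000 nM, and not a number. Compound 2 `O=C1c2ccccc2C(=O)N1C/C=C\Cn1cc(C#CCCc2ccccc2)c(=O)[nH]c1=O`, with a phenyl-bearing alkyne chain on the same core, reads 146000 nM.

Compound 3 `CCCCC#Cc1cn(C/C=C/CN2C(=O)c3ccccc3C2=O)c(=O)[nH]c1=O` is the next analogue to be read. It has hydrogen in place of butyl on a saturated chain carbon, four bonds along the chain from a triple-bonded carbon. Within the data shown here, no measured pair isolates such a change, so the expectation is weakly grounded. It rests mainly on compound 2 at 146000 nM, which shows that this core can return a number in this assay. A small move towards stronger inhibition is expected, as an at least 1.4-fold lower number from compound 1 to compound 3 (0.16 log units; that floor lies within the scatter), and another limit remains possible. For compound 3 the estimated value is 170000 nM, with an expected range of 80000 nM to 250000 nM.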

Compound 3, half-maximal inhibitory concentration: 171000 nM
Beside the measured number, compound 3's estimate is 1.0-fold (0.00 log units) below it; low and high end bracket the measured number.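

In this assay, hydrogen in place of butyl on a saturated chain carbon, four bonds along the chain from a triple-bonded carbon, turns a limit into a number, and the step reads an at least 1.4-fold lower number from compound 1 to compound 3 (0.16 log units; that floor lies within the scatter). Compound 1 stands only at a limit, so this step is a floor on the change and its true size cannot be read: the limit of > 250000 nM in this assay, at which 1 of the 3 values shown sits. Compound 3 therefore supplies the only number shown for a plain alkyl chain on the alkyne of this core.

Going by these compounds, a single step gives no trend with chain length, so it stays open whether a chain shorter than that of compound 3, or one of intermediate length between compound 3 and compound 1, would read differently. Also open, on these data alone, is how an amine or a carboxylic acid at the chain end would read.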